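The compounds below may be only part of what the source reports. "The series", "measured", "known", "first", "only" and "open" are said of these compounds alone.

Working notes on the series.

Compound 1 `COc1ccc(-c2c(C)nn3c(NCc4cccnc4)cc(C)nc23)cc1OC` and compound 2 `COc1ccc(-c2c(C)nn3c(NCC4CCOCC4)cc(C)nc23)cc1OC` share one core, on which the change oxan-4-yl in place of pyridin-3-yl on a saturated chain carbon bound to a nitrogen on an aromatic ring is made. In a physicochemical assay for acid dissociation, compound 1 gives 5.4, and compound 2 gives 5.7; the step of a number 0.30 log units higher from compound 1 to compound 2 (within the scatter).

Compound 3 `COc1ccc(-c2c(C)nn3c(NCc4cccnc4)nc(C)nc23)cc1OC` carries a second core. The difference between the two cores is not broken down here. In this assay compound 3 gives 2.5, the lowest of the three numbers, with the nearest being compound 1 and the furthest compound 2, both beyond the scatter.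

Compound 4 `COc1ccc(-c2c(C)nn3c(NCC4CCOCC4)nc(C)nc23)cc1OC` has not yet been measured. It differs from compound 3 by oxan-4-yl in place of pyridin-3-yl on a saturated chain carbon bound to a nitrogen on an aromatic ring, which is the same change as that from compound 1 to compound 2 in the same place.

Within the data shown here, for compound 4 the expected step in this assay is a number 0.30 log units higher from compound 3 to compound 4 (within the scatter), a step of the same small size as the one seen from compound 1 to compound 2, because that earlier step was a number 0.30 log units higher from compound 1 to compound 2 (within the scatter). The expectation for compound 4 is therefore 2.8, with a range from 2.3 to 3.3.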

Compound 4, acid dissociation constant: 3.1
Compound 4: the middle estimate sits 0.30 log units below what was measured; the range from low to high includes it.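

Working from the printed steps, in this assay the change from pyridin-3-yl to oxan-4-yl gives a number 0.60 log units higher from compound 3 to compound 4 (beyond the scatter), whereas on the core of compound 1 the same change gave a number 0.30 log units higher from compound 1 to compound 2 (within the scatter). The change therefore gives a step beyond the scatter on one core and a step within it on the other, but with a single pair on each core, this shows no rule for how the change carries from one core to another in this series. No measurement is available that bears on the reason for this result.

The compounds shown leave open whether the same two-core comparison would hold for a different group on the saturated chain carbon, such as a piperidin-4-yl ring, which carries an amine, or a carboxylic acid. They also leave open how a longer chain in place of the single chain carbon of (pyridin-3-yl)methyl and (oxan-4-yl)methyl would read on either core.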